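The source may hold more compounds than are shown below. What is called first, only, known or untested is meant among the compounds shown, and "the series" means these compounds.

Working notes on a set sharing one core. Compound 1 `N#Cc1c(Nc2cccc(Cl)c2)nc(SCc2cn(Cc3ccccc3Cl)nn2)nc1-c1ccccc1` gives 3590 nM in a functional assay on B16-F10 cells (Mus musculus) for inhibition, read by MTT assay, with a stated time of 72 h; on this read-out lower numbers stand for stronger inhibition and higher numbers for weaker inhibition. Compound 2 `Cc1cccc(Nc2nc(SCc3cn(Cc4ccccc4Cl)nn3)nc(-c3ccccc3)c2C#N)c1` gives 13500 nM in this assay, and compound 3 `N#Cc1c(Nc2ccc(F)cc2)nc(SCc2cn(Cc3ccccc3Cl)nn2)nc1-c1ccccc1` gives 5340 nM. On these three numbers compound 3 stands second highest; its nearest neighbour is compound 1, with a 1.5-fold higher number from compound 1 to compound 3 (0.17 log units; within the scatter), and its furthest is compound 2, with a 2.5-fold lower number from compound 2 to compound 3 (0.40 log units; beyond the scatter).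

Compound 4 `Cc1ccccc1Nc1nc(SCc2cn(Cc3ccccc3Cl)nn2)nc(-c2ccccc2)c1C#N` has not yet been measured in this assay. The change from compound 3 is 2-methylphenyl in place of 4-fluorophenyl on a nitrogen on an aromatic ring. Among the measured compounds shown here, two measured steps bear on it: a 2.5-fold lower number from compound 2 to compound 3 (0.40 log units; beyond the scatter), where a 3-methylphenyl gave way to the 4-fluorophenyl, and a 3.8-fold higher number from compound 1 to compound 2 (0.58 log units; beyond the scatter), where methyl replaced chloro. Read backwards, the first of these points to a higher number when a methylphenyl returns in place of the fluorophenyl. The methyl in compound 4 sits on the ring at a point not covered by any measured step, so the size is uncertain. For compound 4 a modest rise is expected, a 1.7-fold higher number from compound 3 to compound 4 (0.23 log units; within the scatter). The estimate for compound 4 is 9000 nM, with a range of 4000 nM to 25000 nM.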

Compound 4, half-maximal inhibitory concentration: 2760 nM
For compound 4 the middle estimate is 3.3-fold (0.51 log units) above the measured one; the measured number lies below the stated range.
By their numbers in this assay, from the lowest: compounds 4, 1 and 3 (each within the scatter of the next); then compound 2.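

The methyl's place on the aniline-type ring matters in this assay: moving from 3-methylphenyl to 2-methylphenyl gives a 4.9-fold lower number from compound 2 to compound 4 (0.69 log units; beyond the scatter) and shows that the same group on the same ring can give different numbers. The other two new steps, a 1.9-fold lower number from compound 3 to compound 4 (0.29 log units; within the scatter) and a 1.3-fold lower number from compound 1 to compound 4 (0.11 log units; within the scatter), leave the 2-methylphenyl, 4-fluorophenyl and 3-chlorophenyl compounds unresolved, so among these four compounds only compound 2 stands apart. Nothing given here accounts for the difference between the two methylphenyl compounds.

On these data alone, whether a methoxy or an ethyl group in place of the methyl of compound 4 would keep its number remains open. The nitrile is constant across all four compounds, so the effect of a carboxylic acid at that place is also unknown.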